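The compounds below may be only part of what the source reports. "The series", "measured", "known", "first", "only" and "open" are said of these compounds alone.

Three compounds of a shared core have been examined in a functional assay on the whole organism for inhibition, with Rattus norvegicus as the target, with a stated time of 3.5 h, at a dose of 100 mg/kg by the oral route; a higher number here means more inhibition at the dose given (going by the name of the read-out), a lower number less inhibition. Compound 1 `Clc1ccc(-c2nnc(-c3nsc4ccccc34)o2)cc1` gives 24% in this assay. Compound 2 `COc1ccc(-c2nnc(-c3nsc4ccccc34)o2)cc1` differs from compound 1 by methoxy in place of chloro on an aromatic carbon; in this assay compound 2 gives 29%, and the step of a number 5 percentage points higher from compound 1 to compound 2 (within the scatter) is the only one counted among the measured pairs. Compound 3 `Clc1ccc(Nc2nnc(-c3nsc4ccccc34)o2)cc1` gives 10% in this assay, the lowest of the three numbers; its difference from compound 1 is not broken down here, since the two cores differ in more than one place.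

Compound 4 `COc1ccc(Nc2nnc(-c3nsc4ccccc34)o2)cc1` is the compound still to be measured. It differs from compound 3 by methoxy in place of chloro on an aromatic carbon. This is the same change as the one from compound 1 to compound 2, occurring twice among the compounds shown, and it falls at a place described in the same words in both cases.

The expectation for compound 4 rests on a single precedent: the step of a number 5 percentage points higher from compound 1 to compound 2 (within the scatter) stayed within the scatter, so the step from compound 3 to compound 4 in this assay is expected to be of a comparable size, a number 5 percentage points higher from compound 3 to compound 4 (within the scatter). On that basis compound 4 is estimated to give 15% in this assay, with a range from 0% to 32% considered likely. Whether the second application of the change behaves like the first remains to be seen once compound 4 is measured.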

Compound 4, a percentage reported as inhibition, in the whole organism at one dose (the size of the read-out at that dose, not a potency): 33%
Estimate against measurement, compound 4: 18 percentage points below; measured number outside the range, above it.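

Methoxy in place of chloro on an aromatic carbon, para to a large group, gives a number 23 percentage points higher from compound 3 to compound 4 (beyond the scatter) in this assay, and only on this core does the step lie beyond the scatter. Set beside the earlier step, the same change does not keep its size from one core to the other: the same change on two cores in this assay, a number 5 percentage points higher (within the scatter) from compound 1 to compound 2 and a number 23 percentage points higher (beyond the scatter) from compound 3 to compound 4, 18 percentage points apart, beyond the scatter of two such steps. Within the data shown here, this shows that the step measured on the core of compound 1 could not simply be carried over to the core of compound 3, but with only two pairs, each read at a single oral dose, it does not show what sets the size of the step or what the change would do on a third core.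

The compounds shown leave open whether the difference between the two cores also appears with other groups at the same aromatic carbon, such as an amine, a carboxylic acid or a longer chain in place of methoxy. They also leave open whether the two steps would keep their sizes at other doses, as the whole account rests on one dose and one stated time.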